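From 1,3-thiazol-2-yl to 1,3-oxazol-2-yl

The source may report more compounds than this note shows. Statements on the series, on what has been measured and on what is new or still open speak of the compounds shown alone.

compound 1 `COc1cc(C(=O)c2cn(-c3cccc(C)c3)cc2-c2ccco2)cc(OC)c1OC` gives 23 nM
compound 2 `COc1cc(C(=O)c2cn(-c3cccc(C)c3)cc2-c2nccs2)cc(OC)c1OC` gives 20 nM

Going by the values given here, in a functional assay on MCF7 cells (Homo sapiens) for inhibition, with a stated time of 96 h (a lower number here means a stronger inhibitor, a higher number a weaker inhibitor), compound 2 gives 20 nM and stands within the scatter of compound 1, the only other compound measured. Compound 3 `COc1cc(C(=O)c2cn(-c3cccc(C)c3)cc2-c2ncco2)cc(OC)c1OC` carries 1,3-oxazol-2-yl in place of 1,3-thiazol-2-yl on an aromatic carbon. Among the compounds with values here, the only measured step at this place (a 1.2-fold lower number from compound 1 to compound 2 (0.06 log units; within the scatter)) exchanged furan-2-yl for 1,3-thiazol-2-yl, so no step beyond the scatter is expected here in this assay in either direction. The expected change (a 1.3-fold higher number from compound 2 to compound 3 (0.10 log units; within the scatter)) is correspondingly small. Compound 3 is estimated at 25 nM with an expected range from 10 nM to 60 nM in this measurement.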

Compound 3, half-maximal inhibitory concentration: 75 nM
Compound 3: the middle estimate sits 3.0-fold (0.48 log units) below what was measured, outside the stated range (above it).
By their numbers in this assay, from the lowest: compounds 2 and 1 (each within the scatter of the next); then compound 3.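

Unlike the earlier exchange of furan-2-yl for 1,3-thiazol-2-yl, changing the five-membered aromatic ring at this position can shift the result in this assay: 1,3-oxazol-2-yl in place of 1,3-thiazol-2-yl gives a step beyond the scatter (a 3.8-fold higher number from compound 2 to compound 3 (0.57 log units; beyond the scatter)), and 1,3-oxazol-2-yl in place of furan-2-yl gives another (a 3.3-fold higher number from compound 1 to compound 3 (0.51 log units; beyond the scatter)). Nothing available shows what lies behind these steps. Going by these compounds, how a six-membered pyridin-2-yl ring, an amine or a carboxylic acid at this position would compare remains open.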